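The compounds below may be only part of what the source reports. "The series", "measured", "known", "first", "only" and "open" are said of these compounds alone.

Measured compounds in a functional assay on NCI-H1975 cells (Homo sapiens) for cytotoxicity, read by CCK-8 assay, with a stated time of 72 h; on this read-out lower numbers stand for stronger inhibition and higher numbers for weaker inhibition:
compound 1 `C=CCn1c(=O)/c(=C\c2cc(Br)ccc2F)[nH]c(=O)/c1=C\c1ccccc1OC` — "not active" (no number reported)
compound 2 `COc1ccccc1/C=c1\c(=O)[nH]/c(=C/c2cccc(Cl)c2Cl)c(=O)n1C` — 300 nM
compound 3 `COc1ccccc1/C=c1/[nH]c(=O)/c(=C\c2ccccc2OC)[nH]c1=O` — "not active" (no number reported)

Compound 1 stands without a number in this assay: for compound 1 the read-out is "not active" (no number reported), and compound 3 likewise returned no number. Only compound 2 gives a numbered result, so the position of compound 1 against compound 2 cannot be sized.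

Compound 4 `C=CCn1c(=O)/c(=C\c2ccccc2F)[nH]c(=O)/c1=C\c1ccccc1OC` differs from compound 1 by hydrogen in place of bromo on an aromatic carbon. Among the compounds with values here, no measured pair shows this change. With compound 1 and compound 3 both without a number and compound 2 the only numbered entry, the step is expected to be small, leaving compound 4 weak or again without a number; an outcome beyond the scatter in either direction is not excluded. For compound 4 the expected value in this assay is 8000 nM, with a range of 1500 nM to 40000 nM.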

Compound 4, half-maximal inhibitory concentration: 25100 nM
For compound 4 the middle estimate is 3.1-fold (0.50 log units) below the measured one, and the stated range covers the measured number.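

Within the data shown here, compound 1 carries no number in this assay, so no step to compound 4 can be read. The compounds shown leave open whether 5-bromo-2-fluorophenyl against 2-fluorophenyl shifts the read-out at all. No measurement at hand speaks to a cause.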